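The compounds below may be only part of what the source reports. "The series", "measured", "known", "first", "only" and "open" are said of these compounds alone.

Measured compounds:
- compound 1, `Cc1ccc(S(=O)(=O)N(C)CC(C)C)cc1C#Cc1cc(Cl)ccc1OCC(=O)O`: 4.2 nM
- compound 2, `CS(=O)(=O)c1ccc(F)c(C#Cc2cc(Cl)ccc2OCC(=O)O)c1`: 3.3 nM
- compound 3, `CCCS(=O)(=O)c1cc(C#Cc2cc(Cl)ccc2OCC(=O)O)c(C)cc1NC(C)=O`: 1.3 nM

These three compounds share a core and were each tested in an assay on CHO cells for displacement of a labelled ligand from prostaglandin D2 receptor 2 (Homo sapiens), read by scintillation counting; on this read-out higher numbers stand for weaker inhibition and lower numbers for stronger inhibition. Among them, compound 1 carries the highest number. Compound 2 gives a number that lies within the usual scatter of that of compound 1, so the two cannot be set apart. Compound 3 gives a number that sits beyond the scatter below that of compound 1, so on these three, compound 3 is the one that is clearly apart from compound 1.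

The compound that has not yet been measured is compound 4, `CCS(=O)(=O)c1ccc(C)c(C#Cc2cc(Cl)ccc2OCC(=O)O)c1`. It differs from compound 1 in one place:

ethyl in place of isobutyl(methyl)amino on a sulfonyl sulfur

Among the compounds with values here, no step between measured compounds of the same kind is known. Compound 2 and compound 3 each carry a smaller group on the sulfonyl sulfur than compound 1 does, and their numbers fall at or below that of compound 1, which gives some ground to expect compound 4 to sit at or somewhat below compound 1, though a step of a size that may well lie within the scatter. Compound 4 is therefore expected to give about 3 nM, within a range of 1 nM to 9 nM, which amounts to an expected step of a 1.4-fold lower number from compound 1 to compound 4 (0.15 log units; within the scatter).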

Compound 4, inhibition constant: 8.6 nM
For compound 4 the middle estimate is 2.9-fold (0.46 log units) below the measured one, and the stated range covers the measured number.
By their numbers in this assay, from the lowest: compound 3; then compounds 2 and 1 (each within the scatter of the next); then compound 4.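

In this assay, within the data shown here, putting ethyl in place of isobutyl(methyl)amino on a sulfonyl sulfur gives a 2.0-fold higher number from compound 1 to compound 4 (0.31 log units; beyond the scatter), a modest step that gives the first single-place reading at this position and shows that a smaller group here does not lower the number. Among these compounds, the numbers of compound 2 and compound 3 had hinted at the opposite direction, but both differ from compound 1 in more than one place, so only this step speaks directly to the group on the sulfur. Nothing at hand gives a reason for the step.

Leaving isobutyl(methyl)amino and entering ethyl also replaces a nitrogen on the sulfur with a carbon, so the compounds shown cannot separate the effect of that atom from the effect of chain size. A dimethylamino group or an isobutyl chain on the same sulfur of the core of compound 4 would pull the two apart, and a cyclopropyl group or a longer chain such as butyl would show how the number follows size along the carbon series.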